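A single methyl on the phenyl of compound 2

A few compounds are considered here, and "the series" means these few. Any claim that something is new, unique, unknown or untested is made for them only; others in the source may bear on it.

In a functional assay on KYSE-450 cells (Homo sapiens) for inhibition, read by CCK-8 assay, with a stated time of 48 h (a lower number here means a stronger inhibitor, a higher number a weaker inhibitor), compound 1 `COc1ccc(CN(C(=O)CSC(=S)N2CCN(C(=O)OC(C)(C)C)CC2)c2cc(OC)c(OC)c(OC)c2)cc1` gives 250 nM. Compound 2 `COc1ccc(CN(C(=O)CSC(=S)N2CCN(C(=O)OC(C)(C)C)CC2)c2ccccc2)cc1` gives > 20000 nM, which is a limit of the assay and not a number. Within the data shown here, the one measured step, an at least 80-fold higher number from compound 1 to compound 2 (1.90 log units; beyond the scatter), came with phenyl in place of 3,4,5-trimethoxyphenyl. Compound 3 `COc1ccc(CN(C(=O)CSC(=S)N2CCN(C(=O)OC(C)(C)C)CC2)c2ccc(C)cc2)cc1` carries methyl in place of hydrogen on an aromatic carbon, a methyl in place of hydrogen on an aromatic carbon. It regains no methoxy group, so a large recovery like the reverse of an at least 80-fold higher number from compound 1 to compound 2 (1.90 log units; beyond the scatter) is not expected. The estimated step, an at least 1.3-fold lower number from compound 2 to compound 3 (0.12 log units; that floor lies within the scatter), is small and toward a lower number, if any. For compound 3 the estimated value is 15000 nM, with an expected range from 4000 nM to 30000 nM.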

Compound 3, half-maximal inhibitory concentration: > 20000 nM
Compound 3 gave a limit, no number; the forecaster's own chance of this, stated with the estimate: 60%; at least 1.3-fold (0.12 log units) between middle value and limit.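

Compound 3 also sits at a limit of the assay, not at a number, so a methyl on an aromatic carbon, para to a large group, does not bring the phenyl series back into the readable range. The 4-methylphenyl group still leaves an at least 80-fold higher number from compound 1 to compound 3 (1.90 log units; beyond the scatter), so this single methyl does not stand in for the 3,4,5-trimethoxyphenyl group. The step between compound 2 and compound 3 cannot be read, because both values are limits: the limit of > 20000 nM in this assay, at which 2 of the 3 values shown sit.

Which of the three methoxy groups of compound 1 matters most stays open. So does whether an amine or a chlorine atom at this place would give a measurable value.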